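This account rests on a few compounds, and the source may have more. Where it says the series, first, only, none or still open, it means among the compounds named here.

Measured so far:
Compound 1 `CCOC(=O)n1nc(C)cc1Nc1cc(N2CCN(CC)CC2)nc(N[C@H]2CCN(C(=O)c3ccc(Cl)cc3F)C2)n1` — 4050 ng.h/mL
Compound 2 `CCN1CCN(c2cc(Nc3cc(C)[nH]n3)nc(N[C@H]3CCN(C(=O)c4ccc(Cl)cc4F)C3)n2)CC1` — 533 ng.h/mL

Going by the values given here, in an ADME assay on the whole organism (Mus musculus, strain ICR) for pharmacokinetics, read by LC-MS, with a stated time of 24 h, at a dose of 10 mg/kg by the oral route (a higher number here means more compound in the circulation at the dose given, a lower number less compound in the circulation), compound 2 gives the lower of the two numbers, and the only measured step, a 7.6-fold lower number from compound 1 to compound 2 (0.88 log units; beyond the scatter), shows how far it sits from compound 1. Compound 3 `CCOC(=O)n1nc(Nc2cc(N3CCN(CC)CC3)nc(N[C@H]3CCN(C(=O)c4ccc(Cl)cc4F)C3)n2)cc1C` is not yet measured. It differs from compound 2 by ethoxycarbonyl in place of hydrogen on an aromatic nitrogen, sitting on an aromatic nitrogen of a five-membered aromatic ring with 2 nitrogen. The measured step from compound 1 to compound 2 removed the same group from the other nitrogen of that ring, and the number fell by a 7.6-fold lower number from compound 1 to compound 2 (0.88 log units; beyond the scatter). Among the compounds with values here, compound 3 restores the group, though on the other ring nitrogen, so a rise beyond the scatter is expected, but with only one measured step to rest on, the size is uncertain. The expected step is a 4.7-fold higher number from compound 2 to compound 3 (0.67 log units; beyond the scatter). Compound 3 is therefore estimated at 2500 ng.h/mL, within a range of 900 ng.h/mL to 7000 ng.h/mL.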

Compound 3, area under the concentration-time curve: 961 ng.h/mL
Compound 3: middle estimate off by 2.6-fold (0.42 log units), on the high side; low and high end bracket the measured number.
By their numbers in this assay, from the lowest: compounds 2 and 3 (each within the scatter of the next); then compound 1.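

Placing ethoxycarbonyl on the aromatic nitrogen next to the ring atom that bears a methyl group gives, in this assay, a 1.8-fold higher number from compound 2 to compound 3 (0.26 log units; within the scatter), so at this position the group cannot be told apart from the plain hydrogen. Exchanging 1-(ethoxycarbonyl)-3-methyl-1H-pyrazol-5-yl for 1-(ethoxycarbonyl)-5-methyl-1H-pyrazol-3-yl gives a 4.2-fold lower number from compound 1 to compound 3 (0.62 log units; beyond the scatter), which shows that the same group does not read the same at both placements on this ring. Nothing available here explains why the two placements differ.

The compounds shown leave open how an acetyl or a methoxycarbonyl group would read on either ring nitrogen in this assay. They also leave open whether the gap between the two placements would hold for any group other than ethoxycarbonyl.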